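A few compounds are considered here, and "the series" means these few. Any claim that something is new, unique, unknown or untested is made for them only; others in the source may bear on it.

In a functional assay on HepG2 cells (Homo sapiens) for antiproliferative activity, read by MTT assay, with a stated time of 24 h (on this read-out lower numbers stand for stronger inhibition and higher numbers for weaker inhibition), three compounds sharing one core have been measured. Compound 1 `c1ccc(CSc2nnc(-c3ccc4c(c3)OCCO4)n2-c2ccccc2)cc1` gives 5960 nM, compound 2 `O=[N+]([O-])c1cccc(CSc2nnc(-c3ccc4c(c3)OCCO4)n2-c2ccccc2)c1` gives 49300 nM, and compound 3 `O=[N+]([O-])c1ccc(CSc2nnc(-c3ccc4c(c3)OCCO4)n2-c2ccccc2)cc1` gives 13800 nM, which places compound 3 second highest of the three, between the other two. The next compound, compound 4 `Clc1cccc(CSc2nnc(-c3ccc4c(c3)OCCO4)n2-c2ccccc2)c1`, has not yet been measured. It differs from compound 3 by 3-chlorophenyl in place of 4-nitrophenyl on a saturated chain carbon bound to a sulfur.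

For the measured compounds named here, no compound with a chlorine has been measured, so the available steps bear on this change only indirectly. Nitro in place of hydrogen gave a higher number both times, with an 8.3-fold higher number from compound 1 to compound 2 (0.92 log units; beyond the scatter) and a 2.3-fold higher number from compound 1 to compound 3 (0.36 log units; beyond the scatter). Exchanging 3-nitrophenyl for 4-nitrophenyl gave a 3.6-fold lower number from compound 2 to compound 3 (0.55 log units; beyond the scatter). All three steps are modest. Compound 4 loses the nitro group, and the reverse of a 2.3-fold higher number from compound 1 to compound 3 (0.36 log units; beyond the scatter) points towards a lower number. The 3-nitrophenyl of compound 2 at 49300 nM is a caution against expecting a large gain, so the range is kept wide. A small move towards a lower number is expected, possibly not beyond the scatter, and the estimated step is a 1.7-fold lower number from compound 3 to compound 4 (0.24 log units; within the scatter). For compound 4 the expected value is 8000 nM, with an estimated range from 3000 nM to 22000 nM.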

Compound 4, half-maximal inhibitory concentration: 2390 nM
The estimate for compound 4 lay 3.3-fold (0.52 log units) above the measured number; the measured number lies below the stated range.
By their numbers in this assay, from the lowest: compound 4; then compound 1; then compound 3; then compound 2.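

In this assay, 3-chlorophenyl on a saturated chain carbon bound to a sulfur is the only substituted ring shown that goes to a lower number than the plain phenyl, with a 2.5-fold lower number from compound 1 to compound 4 (0.40 log units; beyond the scatter) against the higher numbers that both nitro compounds gave. Chloro in place of nitro on an aromatic carbon gives a 21-fold lower number from compound 2 to compound 4 (1.31 log units; beyond the scatter) as the only large step in the series, and the change from 4-nitrophenyl to 3-chlorophenyl gives a 5.8-fold lower number from compound 3 to compound 4 (0.76 log units; beyond the scatter) as a modest one, so a substituent on this ring does not always raise the number and the direction follows the group that is present, with compound 2 and compound 3 on one side and compound 4 on the other. Nothing available here explains why chloro and nitro differ in this way.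

From the compounds shown here alone, whether 4-chlorophenyl would keep the order seen in the nitro pair, where the change gave a 3.6-fold lower number from compound 2 to compound 3 (0.55 log units; beyond the scatter) in that direction, remains open. So does the outcome with a methoxy group, an amine or a carboxylic acid on this ring, or with a longer chain in place of the saturated chain carbon bound to a sulfur.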